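Working notes: ethoxycarbonyl on compound 2

The compounds below may be only part of what the source reports. "The series", "measured", "known", "first", "only" and "open" are said of these compounds alone.

Measured in an ADME assay on HeLa cells (Homo sapiens) for cytotoxicity, read by resazurin assay, with a stated time of 65 h; on this read-out lower numbers stand for an effect already at smaller amounts and higher numbers for an effect only at larger amounts of compound:
- compound 1 `CCCCc1cc(C(=O)OCC)c(NC(=O)c2ccc([N+](=O)[O-])o2)s1` gives > 20000 nM
- compound 2 `O=C(Nc1cccs1)c1ccc([N+](=O)[O-])o1` gives > 20000 nM

Compound 2 stands at a limit of this assay, recorded as > 20000 nM, so it has no number of its own. Compound 1 is also a limit, at > 20000 nM. Taken together, the series shows (the limit of > 20000 nM in this assay, at which 2 of the 2 values shown sit), and no measured step is available to give a size.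

Compound 3 `CCOC(=O)c1ccsc1NC(=O)c1ccc([N+](=O)[O-])o1` is still to be measured. It differs from compound 2 by ethoxycarbonyl in place of hydrogen on an aromatic carbon.

No step beyond the usual scatter is expected in this assay, in either direction, and a further reading at the limit is the likeliest outcome, because of the limit of > 20000 nM in this assay, at which 2 of the 2 values shown sit. The expected change is a number no higher from compound 2 to compound 3 (the limit leaves the size open). For compound 3 the estimate is 20000 nM, with an expected range of 8000 nM to 40000 nM.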

Compound 3, half-maximal effective concentration: > 20000 nM
Compound 3 gave a limit, no number; the forecaster's own chance of this, stated with the estimate: 75%; the middle value sits exactly at the limit.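

No step can be read from compound 2 to compound 3 or from compound 1 to compound 3, because all of these values are limits and not numbers: the limit of > 20000 nM in this assay, at which 3 of the 3 values shown sit.

The compounds shown leave open at what concentration any of the three reaches a half-maximal effect in this assay, and whether ethoxycarbonyl or butyl changes that concentration.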